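Chloro on the furan of compound 3: expected effect

The compounds below may be only part of what the source reports. "The series", "measured", "known", "first", "only" and "open" are said of these compounds alone.

Measured compounds and values
- Compound 1, `N#C/C(=C\c1c(F)c(F)c(F)c(F)c1F)C(=O)c1ccc[nH]1`: 64000 nM
- Compound 2, `N#C/C(=C\c1c(F)c(F)c(F)c(F)c1F)C(=O)c1c[nH]c2ccccc12`: 11000 nM
- Compound 3, `COc1ccc(CNC(=O)/C(C#N)=C/c2ccco2)cc1`: 24000 nM

All three numbers come from a functional assay on A2780 cells (Homo sapiens) for inhibition, read by MTT assay, with a stated time of 72 h; on this read-out lower numbers stand for stronger inhibition of growth and higher numbers for weaker inhibition of growth. Compound 1 gives the highest number of the set, compound 2 the lowest, and compound 3 stands second highest of the three. Its nearest neighbour is compound 2, whose number is lower by a margin that lies beyond the usual scatter; its furthest is compound 1, whose number is higher, again beyond the scatter. Within the data shown here, no pair of these three differs in a single place, so none of them supplies a measured step that would guide the next change directly.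

Compound 4, `COc1ccc(CNC(=O)/C(C#N)=C/c2ccc(Cl)o2)cc1`, is the next compound in this assay and differs from compound 3 in one place only: chloro in place of hydrogen on an aromatic carbon. Among the measured compounds shown here, since no measured step of this kind exists in the set, the expectation rests on the general observation that a single small substituent on an aromatic ring tends to move such numbers only modestly. The step from compound 3 to compound 4 is therefore expected to be small, most likely toward a somewhat lower number, a 1.6-fold lower number from compound 3 to compound 4 (0.20 log units; within the scatter), but it may well stay within the scatter. For compound 4 the estimated value is 15000 nM, with a likely range from 5000 nM to 45000 nM.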

Compound 4, concentration for 50% growth inhibition: 9000 nM
The estimate for compound 4 lay 1.7-fold (0.22 log units) above the measured number; measured number inside the range.
By their numbers in this assay, from the lowest: compounds 4 and 2 (each within the scatter of the next); then compound 3; then compound 1.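

In this assay, among these compounds, the change from furan-2-yl to 5-chlorofuran-2-yl gives the first measured single-place step (a 2.7-fold lower number from compound 3 to compound 4 (0.43 log units; beyond the scatter)), and this step is modest but lies beyond the scatter. It shows that this aromatic carbon, next to the ring oxygen and two ring bonds from the ring atom that bears a large group, is a place where one chlorine atom lowers the number, which on this read-out stands for stronger inhibition of growth, rather than leaving it unchanged or raising it. Nothing at hand bears on the reason for this shift.

Going by these compounds, whether the gain belongs to chloro specifically stays open, since the same carbon carrying bromo, methyl, an amine or a carboxylic acid would be needed to show how far the step depends on the group that enters. Also open, on these data alone, is whether the same exchange moves the number by a similar amount when the amide side of compound 4 is changed, for instance with a longer chain in place of its benzyl group.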